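This account rests on a few compounds, and the source may have more. Where it says the series, first, only, none or still open, it means among the compounds named here.

In a functional assay on OVCAR-3 cells (Homo sapiens) for antiproliferative activity, read by spectrophotometry, with a stated time of 2 days (a higher number here means a weaker inhibitor of growth, a lower number a stronger inhibitor of growth), compound 2 `COc1cc(Nc2ncc(C(F)(F)F)c(N3Cc4cccc(N(C)S(C)(=O)=O)c4C3)n2)c(OC)cc1Cl` gives only a limit, > 30000 nM, not an exact number. Compound 4 `COc1cc(Nc2ncc(C(F)(F)F)c(N3Cc4cccc(N(C)S(C)(=O)=O)c4C3)n2)cc(C(F)(F)F)c1` differs from it in one place, on a nitrogen on an aromatic ring, where 3-methoxy-5-(trifluoromethyl)phenyl replaces 4-chloro-2,5-dimethoxyphenyl (3-methoxy-5-(trifluoromethyl)phenyl in place of 4-chloro-2,5-dimethoxyphenyl on a nitrogen on an aromatic ring). For the measured compounds named here, no measured step covers this exact change. The nearest evidence starts from compound 1 `CC(=O)N1CCN(c2ccc(Nc3ncc(C(F)(F)F)c(N4Cc5cccc(N(C)S(C)(=O)=O)c5C4)n3)cc2)CC1`, which gives 970 nM. Compound 3 `CN(c1cccc2c1CN(c1nc(Nc3ccc(Nc4ccccc4)cc3)ncc1C(F)(F)F)C2)S(C)(=O)=O` also gives only a limit, > 50000 nM. The large step of an at least 51-fold higher number from compound 1 to compound 3 (1.71 log units; beyond the scatter) removes the 4-acetylpiperazin-1-yl group, which compound 2 and compound 4 also lack. Compound 4 is therefore expected to stay weak, probably also reaching a limit, with an expected step of a number no higher from compound 2 to compound 4 (the limit leaves the size open) that stays within the scatter. For compound 4 the estimated value is 30000 nM, with an expected range from 10000 nM to 60000 nM.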

Compound 4, concentration for 50% growth inhibition: > 30000 nM
Compound 4 was reported as a limit; the forecaster's own chance of this, stated with the estimate: 75%; the middle value sits exactly at the limit.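

For the compounds shown here, compound 2 and compound 4 each give only a limit, so no step between them can be read: the limit of > 30000 nM in this assay, at which 2 of the 4 values shown sit. The compounds shown leave open which group, 4-chloro-2,5-dimethoxyphenyl or 3-methoxy-5-(trifluoromethyl)phenyl, gives the stronger inhibitor of growth.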